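The source may report more compounds than this note shows. Statements on the series, on what has been measured and on what is new or still open speak of the compounds shown alone.

In a functional assay on SK-MEL-5 cells (Homo sapiens) (on this read-out higher numbers stand for weaker inhibition of growth and lower numbers for stronger inhibition of growth), three compounds have been measured so far:

Compound 1, `Cc1cc(C)c2c(O)cc(-c3ccc(Cl)cc3)nc2n1`, gives 14100 nM.
Compound 2, `COc1ccc(-c2cc(O)c3c(C)cc(C)nc3n2)cc1`, gives 17800 nM.
Compound 3, `Cc1ccnc2nc(-c3ccc(Cl)cc3)cc(O)c12`, gives 3470 nM.

Compound 1 and compound 2 share the same core; they differ by methoxy in place of chloro on an aromatic carbon, and in this assay this gives a 1.3-fold higher number from compound 1 to compound 2 (0.10 log units; within the scatter). Compound 3 keeps the chloro of compound 1 but differs from it by hydrogen in place of methyl on an aromatic carbon, and that change produces a 4.1-fold lower number from compound 1 to compound 3 (0.61 log units; beyond the scatter). Compound 2 stands with the highest of the three numbers, though its gap to compound 1 is within the scatter.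

Compound 4, `COc1ccc(-c2cc(O)c3ccc(C)nc3n2)cc1`, has not yet been measured. It differs from compound 2 by hydrogen in place of methyl on an aromatic carbon. Within the data shown here, this is the same kind of change as the one from compound 1 to compound 3, but not the same: in compound 3 the hydrogen enters next to the ring nitrogen and para to a fused ring, whereas in compound 4 it enters ortho to a fused ring and opposite the ring nitrogen. The two steps therefore do not have to agree.

Among the measured compounds shown here, still, the only guide available is the step from compound 1 to compound 3, and compound 4 is expected to show a 3.2-fold lower number from compound 2 to compound 4 (0.51 log units; beyond the scatter), resting on a 4.1-fold lower number from compound 1 to compound 3 (0.61 log units; beyond the scatter). Compound 4 is thus estimated at 5500 nM in this assay, with a range from 1500 nM to 20000 nM because the position of the change differs.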

Compound 4, concentration for 50% growth inhibition: 47900 nM
For compound 4 the middle estimate is 8.7-fold (0.94 log units) below the measured one; measured number outside the range, above it.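

In this assay, hydrogen in place of methyl on an aromatic carbon gives a 2.7-fold higher number from compound 2 to compound 4 (0.43 log units; beyond the scatter), which runs against the earlier step rather than repeating it. The change therefore does not carry over as a fixed shift from one core to the other, and the two results differ in direction as well as in size: the same change on two cores in this assay, a 4.1-fold lower number (0.61 log units; beyond the scatter) from compound 1 to compound 3 and a 2.7-fold higher number (0.43 log units; beyond the scatter) from compound 2 to compound 4, 11-fold (1.04 log units) apart, beyond the scatter of two such steps. This does not show what sets the two steps apart, since the methyl leaves from a different place in each pair, opposite the ring nitrogen in compound 4, and compound 2 also carries methoxy where compound 1 carries chloro, so the two pairs cannot separate the place of the change from the other group, and two pairs give no rule for the series.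

The compounds shown leave open what hydrogen in place of this same methyl, opposite the ring nitrogen, would do on the chloro core of compound 1, and what the other methyl's removal would do on the methoxy core of compound 2. They also leave open how an ethyl group or an amine would behave at either place in this assay.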